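The source may report more compounds than this note shows. Statements on the series, on what has been measured and on what is new or still open speak of the compounds shown alone.

Measured so far in a functional assay on K562 cells (Homo sapiens) for inhibition, read by fluorescence, with a stated time of 72 h; a higher number here means a weaker inhibitor of growth, a lower number a stronger inhibitor of growth:

- compound 1 `N[C@H]1CC[C@H](Nc2nc(Nc3ccc(Cl)cc3)c3ncn(C4CCCCC4)c3n2)CC1`: 1700 nM
- compound 2 `CCCCCCn1cnc2c(Nc3ccc(O)cc3)nc(N[C@H]3CC[C@H](N)CC3)nc21`: 5400 nM

Only these two numbers are available. Compound 2 has the higher, and so the weaker, result at 5400 nM, while compound 1 gives 1700 nM, a gap beyond the usual scatter of repeated measurements. These two compounds differ in more than one place, so their gap cannot be assigned to any single change.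

The next compound is compound 3 `N[C@H]1CC[C@H](Nc2nc(Nc3ccc(O)cc3)c3ncn(C4CCCCC4)c3n2)CC1`. It differs from compound 2 in one place, with cyclohexyl in place of hexyl on an aromatic nitrogen. Within the data shown here, no measured pair isolates this swap, which leaves only indirect evidence. Compound 1 also carries cyclohexyl on that nitrogen and gives 1700 nM, but it differs elsewhere too, so it is a weak guide. A modest move toward a lower number in this assay therefore seems the likeliest outcome, and it may not clear the scatter. The expected step of a 1.8-fold lower number from compound 2 to compound 3 (0.26 log units; within the scatter) is small. The estimated value for compound 3 is 3000 nM, with a range of 1000 nM to 9000 nM.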

Compound 3, concentration for 50% growth inhibition: 8900 nM
Compound 3: middle estimate off by 3.0-fold (0.47 log units), on the low side; low and high end bracket the measured number.
By their numbers in this assay, from the lowest: compound 1; then compounds 2 and 3 (each within the scatter of the next).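

In this assay, putting cyclohexyl in place of hexyl on the aromatic nitrogen gives a 1.6-fold higher number from compound 2 to compound 3 (0.22 log units; within the scatter), so this assay does not separate the ring from the open chain of six carbons, at least with hydroxy on the aromatic carbon. Among these compounds, the new compound also gives the first single-change reading at that other place: with cyclohexyl kept on the nitrogen, hydroxy in place of chloro gives a 5.2-fold higher number from compound 1 to compound 3 (0.72 log units; beyond the scatter), a step that, unlike the swap on the nitrogen, lies beyond the scatter. Nothing measured here offers an explanation for either step.

The compounds shown leave open whether a clearly different group on the aromatic nitrogen, such as a methyl or a phenyl, would move the number, since the hexyl and cyclohexyl comparison covers only two groups of the same carbon count. They also leave open whether the hydroxy and chloro step keeps its size with hexyl on the nitrogen, and where other groups on the aromatic carbon, such as methoxy or fluoro, would fall.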